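Amide nitrogen substituent swap in a weakly active series

A few compounds are considered here, and "the series" means these few. Any claim that something is new, unique, unknown or untested is made for them only; others in the source may bear on it.

Measured so far:
- compound 1 `CC(C)C(c1ccc(Cl)cc1)S(=O)(=O)Nc1nccs1`: in a functional assay on CHO cells for agonist activity at Free fatty acid receptor 2 (Homo sapiens), read by cAMP accumulation (a higher number here means a weaker inhibitor, a lower number a stronger inhibitor), compound 1 gives > 100000 nM, which is a limit of the assay and not a number.
- compound 2 `CC(C)[C@H](C(=O)NC(C)(C)C)c1ccc(Cl)cc1`: in this assay compound 2 gives > 100000 nM, again a limit of the assay rather than a number.

Compound 2 therefore stands at the upper limit of what this assay reports, and it has no numerical value to compare against; both values shown so far sit at that same limit (the limit of > 100000 nM in this assay, at which 2 of the 2 values shown sit). Nothing about the series has yet been resolved into a number.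

Compound 3 `CC(C)[C@H](C(=O)Nc1ccccc1)c1ccc(Cl)cc1` differs from compound 2 in one place: phenyl in place of tert-butyl on an amide-type nitrogen. For the measured compounds named here, no step between two measured compounds is available to calibrate this change, since neither of the two values shown is a number. The expected step from compound 2 to compound 3 in this assay is a number no higher from compound 2 to compound 3 (the limit leaves the size open), which amounts to no change beyond the scatter, with the likeliest outcome being a further limit. Compound 3 is estimated at 100000 nM in this assay, with a range from 20000 nM to 300000 nM.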

Compound 3, half-maximal inhibitory concentration: > 100000 nM
Compound 3: a limit, no number; the forecaster's own chance of this, stated with the estimate: 75%; the middle value sits exactly at the limit.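

In this assay compound 3 gives > 100000 nM, which is a limit of the assay and not a number. For the compounds shown here, no step can therefore be read for phenyl in place of tert-butyl between compound 2 and compound 3. Going by these compounds alone, the series so far stands at one limit: the limit of > 100000 nM in this assay, at which 3 of the 3 values shown sit. The compounds shown leave open whether any change to the shared core gives a measurable value.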